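A few compounds are considered here, and "the series" means these few. Any claim that something is new, unique, unknown or untested is made for them only; others in the source may bear on it.

Measured so far:
- compound 1 `COc1ccc(/C=C/C(=O)/C=C/c2ccc(OCc3cn(CCCCCOc4cc(=O)oc5ccccc45)nn3)c(OC)c2)cc1OC`: 47%
- compound 2 `COc1cccc(/C=C/C(=O)/C=C/c2ccc(OCc3cn(CCCCCOc4cc(=O)oc5ccccc45)nn3)c(OC)c2)c1`: 37%
- compound 3 `COc1cc(/C=C/C(=O)/C=C/c2cc(OC)c(OC)c(OC)c2)ccc1OCc1cn(CCOc2cc(=O)oc3ccccc23)nn1`: 99%

In a functional assay on THP-1 cells (Homo sapiens) for inhibition, read by sulforhodamine B assay, with a stated time of 48 h, tested at 50 uM (on this read-out lower numbers stand for less inhibition of growth and higher numbers for more inhibition of growth at the one concentration tested), compound 1 gives 47% and compound 2 gives 37%; the two differ by hydrogen in place of methoxy on an aromatic carbon, and the step is a number 10 percentage points lower from compound 1 to compound 2 (within the scatter). Compound 3 gives 99% in this assay; the difference between the core of compound 3 and the core of compound 1 is not broken down here.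

Compound 4 `COc1ccc(/C=C/C(=O)/C=C/c2ccc(OCc3cn(CCOc4cc(=O)oc5ccccc45)nn3)c(OC)c2)cc1OC` is not yet measured. It differs from compound 3 by hydrogen in place of methoxy on an aromatic carbon. This is the same kind of change as from compound 1 to compound 2, not the same: there the place was para to a large group, here it is meta to a large group and meta to a methoxy group.

Going by the values given here, the only measured step of this kind lies within the scatter, but compound 1 stands far below compound 3, which gives 99%, so some fall toward that range is expected. The step expected is a number 21 percentage points lower from compound 3 to compound 4 (beyond the scatter). For compound 4 the estimated value is 78%, between 50% and 98%.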

Compound 4, percent growth inhibition at one concentration: 90%
Compound 4: middle estimate off by 12 percentage points, on the low side, and the stated range covers the measured number.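

In this assay, hydrogen in place of methoxy gives a number 9 percentage points lower from compound 3 to compound 4 (within the scatter), and this step matches the earlier one on the other core: the same change on two cores in this assay, a number 10 percentage points lower (within the scatter) from compound 1 to compound 2 and a number 9 percentage points lower (within the scatter) from compound 3 to compound 4, 1 percentage points apart, within the scatter of two such steps

On these two cores, the change therefore stays within the scatter both where the numbers are low and where they are high, so neither step shows a real effect of removing the methoxy. Two pairs, with the change at different places, do not show that it would carry over to further cores, and a reading at one concentration gives no measure of potency.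

Still open, from the compounds shown here alone, is how a hydroxyl, an amine or a carboxylic acid would read at this place on the ring. Going by these compounds, it is also open whether any of them would move the number beyond the scatter.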